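Swapping the carbamate for a thiourea on a weak inhibitor

The source may hold more compounds than are shown below. What is called first, only, known or untested is meant among the compounds shown, and "the series" means these compounds.

Compound 2, `CCOC(=O)NC1CC(C)(C)Oc2ccc(Cl)cc21`, and compound 1, `CC1(C)CC(NC(=O)NCc2ccccc2)c2cc(Cl)ccc2O1`, share the same core and differ only in the group on the carbonyl carbon. In a functional assay on U-373MG ATCC cells (Homo sapiens) for inhibition, read by MTT assay, with a stated time of 72 h (a higher number here means a weaker inhibitor, a lower number a stronger inhibitor), compound 1 gives 66000 nM. In this assay compound 2 reaches only the limit of the assay, > 100000 nM. The step of an at least 1.5-fold higher number from compound 1 to compound 2 (0.18 log units; that floor lies within the scatter) therefore has a floor that lies within the scatter and sets no firm size, since compound 2 sits at the limit of > 100000 nM in this assay, at which 1 of the 2 values shown sits. Compound 3, `CCNC(=S)NC1CC(C)(C)Oc2ccc(Cl)cc21`, is not yet measured; it differs from compound 2 by a group of 5 heavy atoms (3 carbon, 1 nitrogen, 1 sulfur; no ring) in place of a group of 5 heavy atoms (3 carbon, 2 oxygen; no ring), on an amine nitrogen. Within the data shown here, the only measured step, from compound 1 to compound 2, exchanged a benzylamino group for ethoxy and moved the number toward the limit; the present change goes back toward a nitrogen-bearing group, so no step beyond the scatter, or at most a modest fall, is anticipated. Compound 3 is expected to give 100000 nM, with a range from 40000 nM to 250000 nM. This amounts to an expected step of a number no higher from compound 2 to compound 3 (the limit leaves the size open).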

Compound 3, half-maximal inhibitory concentration: 96000 nM
Estimate against measurement, compound 3: 1.0-fold (0.02 log units) above; the measured number falls inside the stated range.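

Among these compounds, what this position shows for the first time is that a group on the amine nitrogen of this core can return a real number in this assay, with compound 3 at 96000 nM. Compound 2, by contrast, gives only a limit of the assay, > 100000 nM. The exchange of ethoxycarbonyl for the new group gives an at least 1.0-fold lower number from compound 2 to compound 3 (0.01 log units; that floor lies within the scatter), so the change shows no firm gain, and its true size stays unknown: the limit of > 100000 nM in this assay, at which 1 of the 3 values shown sits.

The compounds shown cannot separate the part played by the sulfur from that of the added nitrogen, which a urea carrying the same ethyl group would address. They also leave open whether a longer chain such as butyl, or a benzyl group, on the thiourea nitrogen would move the number beyond the scatter.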